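Chloro in place of hydrogen on compound 3

The compounds below may be only part of what the source reports. "The series", "measured", "known", "first", "only" and "open" are said of these compounds alone.

Of the compounds shown here, three have been read in a functional assay on Bel-7402 cells (Homo sapiens) for inhibition, read by MTT assay, with a stated time of 24 h, tested at 1 ug/mL (on this read-out lower numbers stand for less inhibition of growth and higher numbers for more inhibition of growth at the one concentration tested), and one remains open. Compound 1 (`O=C(CCCCC1CCSS1)Nc1ccc([N+](=O)[O-])c(C(F)(F)F)c1`) gives 7.46% in this read-out. Compound 2 (`O=C(CCCCC(S)CCS)Nc1ccc(Cl)cc1`) gives 0.27% in the same test, and these two values lie within the usual scatter of each other.

Compound 3 (`O=C(CCCCC(CCSC(=O)c1ccccc1)SC(=O)c1ccccc1)Nc1ccccc1`) stands without a single number: its entry reads "not active" (no number reported) in this assay and offers no fixed starting value for a step. Compound 4 (`O=C(CCCCC(CCSC(=O)c1ccccc1)SC(=O)c1ccccc1)Nc1ccc(Cl)cc1`) has yet to be measured.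

The structural change is chloro in place of hydrogen on an aromatic carbon with chloro in place of hydrogen on an aromatic carbon, para to a large group, so that phenyl becomes 4-chlorophenyl. Among the measured compounds shown here, no measured pair isolates this change. Compound 2 also carries the 4-chlorophenyl group and gives 0.27% in this assay at the single concentration tested, so no step beyond the scatter is expected, and any rise in inhibition of growth should stay within it.

For compound 4 the estimated value is 3% with an expected range from 0% to 12% in this assay and an entry without a number remains possible.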

Compound 4, percent growth inhibition at one concentration: 9.62%
Beside the measured number, compound 4's estimate is 6.6 percentage points below it; the measured number falls inside the stated range.
By their numbers in this assay, from the lowest: compounds 2, 1 and 4 (each within the scatter of the next).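

No step can be read from compound 3 to compound 4 in this assay, as compound 3 has no single number to set against compound 4 at 9.62% here. No evidence shown bears on this result. The compounds shown leave open what phenyl to 4-chlorophenyl does on the shared core.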